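The compounds below may be only part of what the source reports. "The series", "measured", "known", "first", "only" and "open" are said of these compounds alone.

Measured compounds:

Compound 1, `CN(C)CCCn1c(N)c(-c2nc3ccccc3[nH]2)c2nc(C#N)c(C#N)nc21`, 1230 nM
Compound 2, `CCN(CC)CCCn1c(N)c(-c2nc3ccccc3[nH]2)c2nc(C#N)c(C#N)nc21`, 1870 nM
Compound 3, `CN(C)CCCn1c(N)c(-c2nc3cc(Cl)ccc3[nH]2)c2nc(C#N)c(C#N)nc21`, 3110 nM

All three were tested in a functional assay on Raji cells (Homo sapiens) for antiproliferative activity, read by MTT assay, with a stated time of 48 h; on this read-out higher numbers stand for weaker inhibition and lower numbers for stronger inhibition. Compound 1 and compound 2 share one core, and the change between them is diethylamino in place of dimethylamino on a saturated chain carbon, three bonds along the chain from an aromatic nitrogen; the step it made was a 1.5-fold higher number from compound 1 to compound 2 (0.18 log units; within the scatter). Compound 3 carries a different core, and the difference between the core of compound 1 and the core of compound 3 is chloro in place of hydrogen on an aromatic carbon; that step was a 2.5-fold higher number from compound 1 to compound 3 (0.40 log units; beyond the scatter). The values of compound 2 and compound 3 lie within the scatter of each other, so nothing is read from that pair.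

Compound 4, `CCN(CC)CCCn1c(N)c(-c2nc3cc(Cl)ccc3[nH]2)c2nc(C#N)c(C#N)nc21`, has not yet been tested. It differs from compound 3 by diethylamino in place of dimethylamino on a saturated chain carbon, three bonds along the chain from an aromatic nitrogen. For the measured compounds named here, this is the same change as the one from compound 1 to compound 2, and it sits in the same place on both cores, so the earlier step is the only guide. Because that step was a 1.5-fold higher number from compound 1 to compound 2 (0.18 log units; within the scatter), compound 4 is expected to sit close to compound 3, with an expected step of a 1.5-fold higher number from compound 3 to compound 4 (0.18 log units; within the scatter). On this basis the estimate for compound 4 in this assay is 4700 nM, expected to fall between 2400 nM and 9500 nM. The wider range reflects that this rests on a single earlier pair carried onto a second core.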

Compound 4, half-maximal inhibitory concentration: 1620 nM
The estimate for compound 4 lay 2.9-fold (0.46 log units) above the measured number, outside the stated range (below it).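

On the core of compound 3 in this assay, diethylamino in place of dimethylamino gave a 1.9-fold lower number from compound 3 to compound 4 (0.28 log units; within the scatter), and chloro in place of hydrogen, read on the diethylamino compounds, gave a 1.2-fold lower number from compound 2 to compound 4 (0.06 log units; within the scatter). Each step taken alone stays within the scatter, but set beside its earlier counterpart the diethylamino change did not keep its size from one core to the other: the same change on two cores in this assay, a 1.5-fold higher number (0.18 log units; within the scatter) from compound 1 to compound 2 and a 1.9-fold lower number (0.28 log units; within the scatter) from compound 3 to compound 4, 2.9-fold (0.47 log units) apart, beyond the scatter of two such steps The chloro change gives the same picture, but the two comparisons rest on the same four compounds and so are not independent, and they show neither a rule for other cores nor a reason for the difference: the same change on two cores in this assay, a 2.5-fold higher number (0.40 log units; beyond the scatter) from compound 1 to compound 3 and a 1.2-fold lower number (0.06 log units; within the scatter) from compound 2 to compound 4, 2.9-fold (0.47 log units) apart, beyond the scatter of two such steps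

The compounds shown leave open whether a longer chain between the aromatic nitrogen and the amine, or a dipropylamino group in place of diethylamino, would follow either earlier step. They also leave open how the diethylamino change would behave on a core carrying fluoro or methoxy in place of chloro.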